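Dropping the Nitrile: From Compound 2 to Compound 3

The compounds below may be only part of what the source reports. "The series", "measured", "known", "first", "only" and "open" are said of these compounds alone.

Compound 1 `Cn1cnnc1SCC(=O)N/N=c1/scc(-c2ccc(C#N)cc2)n1-c1ccccc1` and compound 2 `Cn1nnnc1SCC(=O)N/N=c1/scc(-c2ccc(C#N)cc2)n1-c1ccccc1` share one core and differ only in the group on the sulfur. In a functional assay on C6 cells (Rattus norvegicus) for cytotoxicity, read by MTT assay, with a stated time of 24 h, tested at 6 ug/mL (a higher number here means a weaker effect of the compound at the concentration tested, a lower number a stronger effect), compound 1 gives 70.2% and compound 2 gives 63.5%; the step of a number 6.7 percentage points lower from compound 1 to compound 2 (within the scatter) does not separate them. Compound 2 stands as the lowest of the two numbers, and the nearest, compound 1, lies within the scatter of it. Compound 3 `Cn1nnnc1SCC(=O)N/N=c1/scc(-c2ccccc2)n1-c1ccccc1` keeps the 1-methyl-1H-tetrazol-5-yl group of compound 2 and changes only the far end: hydrogen in place of cyano on an aromatic carbon. Going by the values given here, no measured step touches this cyano group; the single step available, a number 6.7 percentage points lower from compound 1 to compound 2 (within the scatter), concerns the group on the sulfur and was within the scatter. With no guide to the change, no step beyond the scatter is expected in this assay. Compound 3 is therefore estimated at 64%, between 50% and 78%, an expected step of a number 0.5 percentage points higher from compound 2 to compound 3 (within the scatter).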

Compound 3, a percentage reported as activity, at one concentration (the size of the read-out at that concentration, not a potency): 85.2%
For compound 3 the middle estimate is 21.2 percentage points below the measured one; measured number above the stated range.
By their numbers in this assay, from the lowest: compounds 2 and 1 (each within the scatter of the next); then compound 3.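

In this assay, going by these compounds alone, the step of a number 21.7 percentage points higher from compound 2 to compound 3 (beyond the scatter) is the first to lie beyond the scatter, so the effect responds to a change at the far end of the molecule, whereas the one change on the sulfur did not separate compound 1 from compound 2. With the 1-methyl-1H-tetrazol-5-yl group held constant, going from 4-cyanophenyl to phenyl gives a weaker effect at the concentration tested, which shows that this place on the six-membered aromatic ring is not indifferent to its substituent. Nothing available explains why the loss of the cyano group has this result.

The compounds shown leave open whether a chlorine atom, a methoxy group or an amine at this place would preserve the effect seen with cyano. They also leave open whether the same change would give a similar step with the 4-methyl-4H-1,2,4-triazol-3-yl group on the sulfur.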